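Series notes: N-substituent change on the core of compound 2

The source may hold more compounds than are shown below. What is called first, only, known or untested is meant among the compounds shown, and "the series" means these compounds.

Measured so far:
compound 1 `O=C(Cn1nnc(-c2ccccc2)n1)NC1CC2CCC1C2` — 13%
compound 2 `Cc1cc(NC(=O)Cn2nnc(-c3ccccc3)n2)n(C(C)C)n1` — 107%

In an assay on HEK293 cells for activation of Kir3.1/Kir3.2 (Homo sapiens), read by thallium flux (a lower number here means a smaller maximal response, a higher number a larger maximal response), compound 1 gives 13%, while compound 2 gives 107%. Compound 2 thus stands highest of the two numbers available, and its gap to compound 1 is beyond the usual scatter. Within the data shown here, the two compounds share the phenyl-tetrazole acetamide part and differ in the whole group on the amide nitrogen, so no single-point step between measured compounds can be read from them.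

Compound 3 `Cc1cc(NC(=O)Cn2nnc(-c3ccccc3)n2)n(CC2CCCCC2)n1` keeps the core of compound 2 and changes only one place: cyclohexylmethyl in place of isopropyl on an aromatic nitrogen. The change sits on an aromatic nitrogen of a five-membered aromatic ring with 2 nitrogen, next to the ring atom that bears a large group.

Among the measured compounds shown here, no measured pair shows what enlarging this substituent does in this assay. The maximal response of compound 2 is already near the reference, so the expected step of a number 17 percentage points lower from compound 2 to compound 3 (beyond the scatter) is small and, if anything, downward, with a fair chance that it stays within the scatter. Compound 3 is estimated at 90%, with a range from 55% to 115%.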

Compound 3, largest response reached (Emax), in percent of the reference or control that the assay uses: 77%
Beside the measured number, compound 3's estimate is 13 percentage points above it; the measured number falls inside the stated range.
By their numbers in this assay, from the lowest: compound 1; then compound 3; then compound 2.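

In this assay, the substituent on the aromatic nitrogen of the shared core now has its first measured step: cyclohexylmethyl in place of isopropyl gives a number 30 percentage points lower from compound 2 to compound 3 (beyond the scatter) and lies beyond the usual scatter, so the maximal response at this position depends on the group carried there. The step is modest, and compound 3 still reaches 77%, so this position accepts a group with a six-membered non-aromatic ring of carbon only without the response being lost. Nothing available explains the loss from isopropyl to cyclohexylmethyl.

The single step changes two things together, the ring and the total size of the group, and the compounds shown do not separate them: cyclohexyl placed directly on the aromatic nitrogen, or an open n-hexyl chain, would help to tell them apart. As far as these compounds go, it also remains open how the response changes with a phenyl or benzyl group here, or with a chain that ends in an amine or a carboxylic acid.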